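Shortening the Alkylamino Chain on a Weak Adenosine Binder

A few compounds are considered here, and "the series" means these few. Any claim that something is new, unique, unknown or untested is made for them only; others in the source may bear on it.

Compound 1, `CCCNc1nc(-c2ccccc2)nc2c1nnn2Cc1ccccc1`, was measured in an assay on isolated protein for binding affinity to adenosine receptor A1 (Bos taurus) (a lower number here means a stronger inhibitor, a higher number a weaker inhibitor), and gave 37000000 nM, the highest of the two numbers in hand. Compound 2, `CCNc1nc(-c2ccccc2)nc2c1nnn2Cc1ccccc1F`, gave 11000000 nM in this assay, a gap from compound 1 beyond the usual scatter. Compound 3, `CNc1nc(-c2ccccc2)nc2c1nnn2Cc1ccccc1`, has not yet been measured; it differs from compound 1 by hydrogen in place of ethyl on a saturated chain carbon bound to a nitrogen on an aromatic ring, which read one bond further out is propyl to methyl. Going by the values given here, with no measured pair showing this change, a step of modest size, in either direction or none beyond the scatter, is expected: a 1.1-fold higher number from compound 1 to compound 3 (0.03 log units; within the scatter). The estimate for compound 3 is 40000000 nM, between 10000000 nM and 150000000 nM.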

Compound 3, inhibition constant: 353000000 nM
Beside the measured number, compound 3's estimate is 8.8-fold (0.95 log units) below it, outside the stated range (above it).
By their numbers in this assay, from the lowest: compound 2; then compound 1; then compound 3.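

In this assay, the position carrying the chain is sensitive to its length: replacing propylamino with methylamino gives a 9.5-fold higher number from compound 1 to compound 3 (0.98 log units; beyond the scatter), so the longer chain is favoured in this pair. Going by these compounds alone, this is the first measured step at this position, and it moves towards weaker binding. Nothing in hand bears on why the number rises. Still open, on these data alone, is whether an ethylamino chain on the core of compound 1 would stand nearer propylamino or methylamino. Also open, as far as these compounds go, is whether a butyl chain or a cyclopropyl group here would lower the number below that of compound 1.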